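Swapping Isopropyl for Cyclopropyl on a Small Amide

The source may report more compounds than this note shows. Statements on the series, on what has been measured and on what is new or still open speak of the compounds shown alone.

- compound 1 `COC(=O)C(=O)N[C@@H](CO)C(=O)O` reads "not determined" (no result reported)
- compound 2 `CC(C)C(=O)N[C@@H](CO)C(=O)O` reads 49%

Among the compounds with values here, both entries come from an ADME assay on microsomes from liver (Mus musculus) for metabolic stability, with a stated time of 30 min (a higher number here means that more of the compound is left, a lower number that less of the compound is left), and compound 2 at 49% holds the only number so far. Compound 1 has no result, so there is nothing to rank compound 2 against, and a single value cannot show whether it is high or low for this kind of compound.

Compound 3 `O=C(N[C@@H](CO)C(=O)O)C1CC1` has not yet been measured in this assay and differs from compound 2 in one place, with cyclopropyl in place of isopropyl on a carbonyl carbon as the counted difference. In words, this is cyclopropyl in place of isopropyl on a carbonyl carbon whose other neighbour is an amide-type nitrogen.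

Within the data shown here, no pair of measured compounds shows what such a swap does, so the best starting point is compound 2 at 49% and no firm direction can be argued. A change beyond the usual scatter is not expected, and the estimated a number 3 percentage points higher from compound 2 to compound 3 (within the scatter) is small. For compound 3 the expected value is 52% with an estimated range from 35% to 70% as the likely span.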

Compound 3, percent of the compound remaining: 21%
The estimate for compound 3 lay 31 percentage points above the measured number; the whole stated range lies above it.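

The first measured pair shows that this position on the carbonyl carbon is not indifferent in this assay: cyclopropyl in place of isopropyl gives a number 28 percentage points lower from compound 2 to compound 3 (beyond the scatter). The two groups have the same count of heavy atoms, all carbon, and neither carries a hydrogen-bond donor or acceptor, so the counted difference between them is the three-membered ring. No measurement here explains why the read-out falls, and the result records only the size and direction of this one step.

The compounds shown leave open how other groups on the same carbonyl carbon would read, such as cyclobutyl, a larger ring of carbon, or n-butyl, a longer chain, and whether either would stay closer to isopropyl or to cyclopropyl. As far as these compounds go, it also remains open whether the same swap would give a step of similar size on another core, as this is a single pair on one small amide.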